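The source may hold more compounds than are shown below. What is called first, only, known or untested is meant among the compounds shown, and "the series" means these compounds.

Measured in an ADME assay on HCT-116 cells (Homo sapiens) for cytotoxicity, read by CellTiter-Glo, with a stated time of 72 h (on this read-out higher numbers stand for weaker inhibition and lower numbers for stronger inhibition), each entry a limit rather than a number:

- Compound 1 `Cc1cc(C)c(S(=O)(=O)N2CCC(c3ccccc3)CC2)c(C)c1`: > 5000 nM
- Compound 2 `Cc1ccc(C2CCN(S(=O)(=O)c3c(C)cc(C)cc3C)CC2)cc1`: > 5000 nM
- Compound 3 `Cc1cc(C)c(S(=O)(=O)N2CCC(N3CCN(C)CC3)CC2)c(C)c1`: > 5000 nM

Compound 3 therefore has no exact position on the scale, and its entry is only a limit. All three compounds stand alike here, as the limit of > 5000 nM in this assay, at which 3 of the 3 values shown sit, shows.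

Compound 4 `Cc1cc(C)c(S(=O)(=O)N2CCC(N3CC(C)CC(C)C3)CC2)c(C)c1` carries 3,5-dimethylpiperidin-1-yl in place of 4-methylpiperazin-1-yl on a saturated ring carbon.

The measured changes at that same carbon are a step that the two limits leave unreadable from compound 1 to compound 3 and a step that the two limits leave unreadable from compound 2 to compound 3. Neither gives a size to carry over, and the swaps they cover left every compound at the limit. The smaller change on the aromatic ring, a step that the two limits leave unreadable from compound 1 to compound 2, gives no size either. No step beyond the usual scatter is therefore expected in this assay, in either direction.

For compound 4 the expected value is about 6000 nM.

For compound 4 the estimated range runs from 1500 nM to 15000 nM.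

The estimate amounts to an expected step that the limit leaves unreadable from compound 3 to compound 4.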

Compound 4, half-maximal inhibitory concentration: > 5000 nM
Compound 4 ended at the assay's limit; the forecaster's own chance of this, stated with the estimate: 75%; the middle value lies beyond the limit too.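

Compound 4 sits at the same assay limit as compound 1, compound 2 and compound 3, so no step between compound 4 and any of them can be read: the limit of > 5000 nM in this assay, at which 4 of the 4 values shown sit.

The compounds shown leave open whether any of these groups on the saturated ring carbon changes the result in this assay, as none has an exact value.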